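Mirror-image pyrrolidine and lysosomal alpha-glucosidase inhibition

The source may report more compounds than this note shows. Statements on the series, on what has been measured and on what is new or still open speak of the compounds shown alone.

Compound 1 `OC[C@]1(c2ccc(F)cc2)NC[C@H](O)[C@H]1O`: 101000 nM
Compound 2 `C[C@@]1(CO)NC[C@H](O)[C@H]1O`: 2900 nM

In an assay on isolated protein for inhibition of lysosomal alpha-glucosidase (Rattus norvegicus), read by colorimetric assay (a lower number here means a stronger inhibitor, a higher number a weaker inhibitor), compound 2 gives 2900 nM, the lower of the two numbers recorded so far; compound 1 gives 101000 nM, a gap that lies beyond the scatter. Compound 3 `C[C@]1(CO)NC[C@@H](O)[C@@H]1O` has not yet been measured. It differs from compound 2 only in configuration: the two compounds have the same atoms and bonds and differ only in configuration as drawn: 3 of 3 stereo elements differ (all stereocentres are inverted: mirror images); a stereocentre at a saturated ring carbon is drawn S in compound 2 and R in compound 3; a stereocentre at a saturated ring carbon is drawn S in compound 2 and R in compound 3; a stereocentre at a saturated ring carbon is drawn S in compound 2 and R in compound 3. Among the compounds with values here, no measured pair in this set shows what inverting all stereocentres does, so the size of the step in this assay is uncertain. Because compound 2 gives 2900 nM with one particular arrangement of its three stereocentres, the expectation for its mirror image is a weaker inhibitor, with the step of a 10-fold higher number from compound 2 to compound 3 (1.01 log units; beyond the scatter) estimated to go towards a higher number. Compound 3 is therefore expected to give about 30000 nM in this assay, with a plausible range from 3000 nM to 300000 nM.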

Compound 3, half-maximal inhibitory concentration: 830 nM
Compound 3: the middle estimate sits 36-fold (1.56 log units) above what was measured; the whole stated range lies above it.
By their numbers in this assay, from the lowest: compound 3; then compound 2; then compound 1.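

In this assay, within the data shown here, this pair is the first to isolate configuration, and inverting all three stereocentres gives a 3.5-fold lower number from compound 2 to compound 3 (0.54 log units; beyond the scatter), so the mirror-image arrangement is the stronger of the two here, not the weaker. The change is modest but beyond the scatter, which shows that this enzyme assay distinguishes the two mirror-image forms and that the form of compound 2 is not the preferred one of this pair. The step can be assigned to stereochemistry alone, because nothing else separates the pair: the fact that compounds 2 and 3 differ only in the configuration as drawn.

The compounds shown do not reveal which of the three stereocentres carries the step, since only full inversion appears. On these data alone, it also remains open whether the same preference would hold with an ethyl group, a longer chain or a carboxylic acid on the core of compound 3.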